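Trifluoromethyl added to the pyrimidine ether of compound 3

A few compounds are considered here, and "the series" means these few. Any claim that something is new, unique, unknown or untested is made for them only; others in the source may bear on it.

Compound 3 `CC(C)[C@H](NC(=O)COc1cccc2ccccc12)C(=O)N[C@@H](CC(=O)O)C(=O)COc1ccncn1` sits at a limit in a functional assay on Jurkat cells (Homo sapiens) for inhibition; a higher number here means a weaker inhibitor, a lower number a stronger inhibitor: in this assay compound 3 gives > 200000 nM, a limit rather than a number. Compound 1 `CCOC(=O)c1c(C)noc1OCC(=O)[C@H](CC(=O)O)NC(=O)[C@@H](NC(=O)COc1cccc2ccccc12)C(C)C` gives in this assay > 200000 nM, also a limit. Compound 2 `CC(C)[C@H](NC(=O)COc1cccc2ccccc12)C(=O)N[C@@H](CC(=O)O)C(=O)CSc1nc[nH]n1` gives in this assay > 200000 nM, likewise a limit. The steps a step that the two limits leave unreadable from compound 1 to compound 2, a step that the two limits leave unreadable from compound 1 to compound 3 and a step that the two limits leave unreadable from compound 2 to compound 3 are unreadable in size since (the limit of > 200000 nM in this assay, at which 3 of the 3 values shown sit). Compound 4 `CC(C)[C@H](NC(=O)COc1cccc2ccccc12)C(=O)N[C@@H](CC(=O)O)C(=O)COc1ccnc(C(F)(F)F)n1` differs from compound 3 by trifluoromethyl in place of hydrogen on an aromatic carbon. For the measured compounds named here, no measured step bears on this change, and nothing in this assay gives it a direction. Compound 4 is expected to remain at the limit, an expected step of a number no higher from compound 3 to compound 4 (the limit leaves the size open). Compound 4 is therefore estimated at 200000 nM in this assay, within 100000 nM to 400000 nM.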

Compound 4, half-maximal inhibitory concentration: 37000 nM
The estimate for compound 4 lay 5.4-fold (0.73 log units) above the measured number, and the stated range ends above it.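

In this assay the 2-(trifluoromethyl)pyrimidin-4-yl ether is the only group shown that leaves the limit, with trifluoromethyl between two ring nitrogen atoms: an at least 5.4-fold lower number from compound 3 to compound 4 (0.73 log units; beyond the scatter). Against the other two groups the change reads an at least 5.4-fold lower number from compound 2 to compound 4 (0.73 log units; beyond the scatter) and an at least 5.4-fold lower number from compound 1 to compound 4 (0.73 log units; beyond the scatter). The steps among compounds 1, 2 and 3 cannot be read, and these three new sizes are only floors: the limit of > 200000 nM in this assay, at which 3 of the 4 values shown sit.

On these data alone, whether methyl, chlorine or a nitrile on this same carbon also leaves the limit stays open. So does whether pentafluoroethyl there goes further than trifluoromethyl.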